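Compound 2 to compound 3: methoxy gives way to methyl

A few compounds are considered here, and "the series" means these few. Any claim that something is new, unique, unknown or untested is made for them only; others in the source may bear on it.

Measured so far:
- compound 1 `COc1ccc2c(c1)CCc1c(-c3ccccc3)c3n(c1-2)[B-](F)(F)[N+]1=C(c2ccc(C)cc2)C(Br)=C(c2ccccc2)C1=N3` gives > 50000 nM, a limit
- compound 2 `COc1ccc(C2=[N+]3C(=Nc4c(-c5ccccc5)c5c(n4[B-]3(F)F)-c3ccc(OC)cc3CC5)C(c3ccccc3)=C2I)cc1` gives > 50000 nM, a limit

In a toxicity assay on HeLa cells (Homo sapiens) for cytotoxicity, read by MTT assay, with a stated time of 3 h (a lower number here means a stronger inhibitor, a higher number a weaker inhibitor), compound 2 gives > 50000 nM, which is a limit of the assay and not a number. Compound 2 stands at the limit of > 50000 nM in this assay, at which 2 of the 2 values shown sit. Compound 1 offers no graded number to set beside it, since its value is also a limit.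

Compound 3 `COc1ccc2c(c1)CCc1c(-c3ccccc3)c3n(c1-2)[B-](F)(F)[N+]1=C(c2ccc(C)cc2)C(I)=C(c2ccccc2)C1=N3` differs from compound 2 in one place, with methyl in place of methoxy on an aromatic carbon, para to a large group: methyl in place of methoxy on an aromatic carbon. The same difference reads 4-methoxyphenyl to 4-methylphenyl.

For the measured compounds named here, no step between measured compounds is available, so the size of this change can only be expected. In this assay the expected step of a number no higher from compound 2 to compound 3 (the limit leaves the size open) is none beyond the scatter. That expectation rests on compound 2, which gives > 50000 nM, a limit. The estimate for compound 3 is 50000 nM, with an expected range from 25000 nM to 100000 nM.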

Compound 3, half-maximal inhibitory concentration: > 50000 nM
Compound 3: a limit, no number (the forecaster's own chance of this, stated with the estimate: 80%); the middle value sits exactly at the limit.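

In this assay compound 3 gives > 50000 nM, a limit of the assay and not a number. Its steps from compound 1 and from compound 2 cannot be read: the limit of > 50000 nM in this assay, at which 3 of the 3 values shown sit. The compounds shown hold no graded number and leave open whether exchanging methoxy for methyl, or bromo for iodo, alters cytotoxicity at all.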